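Removing one methoxy group from compound 1

The source may report more compounds than this note shows. Statements on the series, on what has been measured and on what is new or still open speak of the compounds shown alone.

Measured compounds:
- compound 1 `COc1cc(-c2cc(/C=C/C(=O)c3ccc(N)cc3)[nH]n2)cc(OC)c1OC` gives 78% in a functional assay on NCI-H460 cells (Homo sapiens) for cytotoxicity, read by sulforhodamine B assay, with a stated time of 48 h, tested at 1 uM; on this read-out higher numbers stand for a weaker effect at the one concentration tested and lower numbers for a stronger effect
- compound 2 `COc1ccc(-c2cc(/C=C/C(=O)c3ccc(OC)c(OC)c3)[nH]n2)cc1` gives 75% in this assay
- compound 3 `COc1cc(-c2cc(/C=C/C(=O)c3ccc(Cl)c(Cl)c3)[nH]n2)cc(OC)c1OC` gives 93% in this assay

Among these three numbers, compound 1 stands second highest. Its nearest neighbour is compound 2, whose number lies within the scatter of that of compound 1, so the two cannot be told apart. Compound 3 lies further away: the step of a number 15 percentage points higher from compound 1 to compound 3 (beyond the scatter) is beyond the scatter and of modest size. The structural change of that step sits on the carbonyl side of the shared core.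

Compound 4 `COc1ccc(-c2cc(/C=C/C(=O)c3ccc(N)cc3)[nH]n2)cc1OC` has not yet been measured. It differs from compound 1 in one place: hydrogen in place of methoxy on an aromatic carbon. Among the measured compounds shown here, this change sits on the other aromatic ring, the one attached to the core, not on the carbonyl side where the one measured step was made. For the measured compounds named here, no measured step therefore bears directly on it; compound 2 also carries fewer methoxy groups on that ring, but it differs from compound 1 in a second place as well, so its number cannot be read as a single step. With nothing pointing in either direction, the expectation for compound 4 in this assay is a step of a number 2 percentage points higher from compound 1 to compound 4 (within the scatter), which is within the scatter. Compound 4 is estimated at 80%, with a range from 62% to 96%.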

Compound 4, a percentage reported as activity, at one concentration (the size of the read-out at that concentration, not a potency): 94%
Compound 4: the middle estimate sits 14 percentage points below what was measured; measured number inside the range.
By their numbers in this assay, from the lowest: compounds 2 and 1 (each within the scatter of the next); then compounds 3 and 4 (each within the scatter of the next).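

With hydrogen in place of methoxy on the aromatic ring that keeps the other methoxy groups, the result is a number 16 percentage points higher from compound 1 to compound 4 (beyond the scatter) in this assay, and on this read-out a higher number means a weaker effect at the one concentration tested. The methoxy group that leaves, ortho to a methoxy group and meta to a large group, therefore matters to the effect of compound 1, even though it is only a small part of the molecule. Among the compounds shown here, until now the only measured single change lay on the carbonyl side, a number 15 percentage points higher from compound 1 to compound 3 (beyond the scatter) and this new step shows that a change on the other aromatic ring can also move the number beyond the scatter. Nothing available explains why removing this methoxy group weakens the effect.

From the compounds shown here alone, with only methoxy and hydrogen compared at this place, it remains open how a hydroxy group, a fluorine atom or an ethoxy group there would behave. Going by these compounds, it is also open whether the same step would appear with 3,4-dichlorophenyl in place of 4-aminophenyl, and how it would look across several concentrations rather than at a single one.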